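The source may hold more compounds than are shown below. What is called first, only, known or untested is meant among the compounds shown, and "the series" means these compounds.

The shared core, seen in compound 1 `COc1ccc(-n2c(S)nnc2-c2cc(OC)c(OC)c(OC)c2)cc1`, carries a thiol on the triazole that is varied across the set. In a functional assay on HT-29 cells (Homo sapiens) for inhibition, read by MTT assay, with a stated time of 48 h (a lower number here means a stronger inhibitor, a higher number a weaker inhibitor), compound 1 returns only a limit, > 60000 nM. Compound 2 `COc1ccc(-n2c(SCc3ccccc3)nnc2-c2cc(OC)c(OC)c(OC)c2)cc1` has benzyl in place of hydrogen on that sulfur. In this assay compound 2 likewise returns only a limit, > 60000 nM. Compound 3 `CCOC(=O)CSc1nnc(-c2cc(OC)c(OC)c(OC)c2)n1-c1ccc(OC)cc1` carries (ethoxycarbonyl)methyl on the sulfur. In this assay compound 3 again returns only a limit, > 60000 nM. The step that the two limits leave unreadable from compound 1 to compound 2 and the step that the two limits leave unreadable from compound 2 to compound 3 are therefore of unreadable size, because of the limit of > 60000 nM in this assay, at which 3 of the 3 values shown sit.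

Compound 4 `COc1ccc(NC(=O)CSc2nnc(-c3cc(OC)c(OC)c(OC)c3)n2-c2ccc(OC)cc2)cc1` is the next member; against compound 2 the difference is (4-methoxyphenyl)carbamoyl in place of phenyl on a saturated chain carbon bound to a sulfur. The measured step that bears on it is the one on the same saturated chain carbon bound to a sulfur, from compound 2 to compound 3, and that step is unreadable because of the limit of > 60000 nM in this assay, at which 3 of the 3 values shown sit. For the measured compounds named here, no measured step in this set shows a readable change in this assay, so no step beyond the scatter is expected from compound 2 to compound 4, and the estimated step is a number no higher from compound 2 to compound 4 (the limit leaves the size open). The value for compound 4 in this assay is estimated at 60000 nM, with a range from 20000 nM to 200000 nM, most likely again reported only as a limit.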

Compound 4, half-maximal inhibitory concentration: 45300 nM
For compound 4 the middle estimate is 1.3-fold (0.12 log units) above the measured one, and the stated range covers the measured number.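

In this assay, for the compounds shown here, compound 4 is the first member of the series to return a number rather than a limit, 45300 nM, so a change on the saturated chain carbon bound to a sulfur can yield a readable value in this read-out. (4-Methoxyphenyl)carbamoyl in place of phenyl gives an at least 1.3-fold lower number from compound 2 to compound 4 (0.12 log units; that floor lies within the scatter), (4-methoxyphenyl)amino in place of ethoxy on the carbonyl carbon gives an at least 1.3-fold lower number from compound 3 to compound 4 (0.12 log units; that floor lies within the scatter), and ((4-methoxyphenyl)carbamoyl)methyl in place of hydrogen on the sulfur gives an at least 1.3-fold lower number from compound 1 to compound 4 (0.12 log units; that floor lies within the scatter). All three steps are floors rather than sizes, so the change may be anywhere from negligible to large, and the compounds it is compared with cannot settle this: the limit of > 60000 nM in this assay, at which 3 of the 4 values shown sit.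

On these data alone, it remains open whether the readable value goes with the carbamoyl link or with the 4-methoxyphenyl ring, a question that an unsubstituted phenylcarbamoyl or a plain carbamoyl on the same carbon would address. Also open, as far as these compounds go, is how a carboxylic acid in place of the ester of compound 3, or a longer chain on the sulfur, would behave in this assay.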